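The source may report more compounds than this note shows. Statements on the series, on what has been measured and on what is new or still open speak of the compounds shown alone.

Measured in a functional assay on MCF7 cells (Homo sapiens) for inhibition, read by MTT assay, with a stated time of 72 h; on this read-out lower numbers stand for stronger inhibition and higher numbers for weaker inhibition:
compound 1 `C=C(Br)C(=O)Nc1cccc(/C=C/C(=O)Nc2ccccc2)c1` gives 27300 nM
compound 2 `C=C(Br)C(=O)Nc1cccc(/C=C/C(=O)Nc2cccc3ccccc23)c1` gives 2800 nM

Of these two numbers, compound 1 stands at the higher one; the number for compound 2 lies well below it, beyond the usual scatter. Compound 3 `C=C(Br)C(=O)Nc1cccc(/C=C/C(=O)Nc2ccc(Cl)cc2)c1` has not yet been measured in this assay. It differs from compound 1 by a single change: chloro in place of hydrogen on an aromatic carbon. Within the data shown here, no measured pair shows this change, so nothing in the data fixes its size. A modest downward step is expected, a 1.8-fold lower number from compound 1 to compound 3 (0.26 log units; within the scatter), near the edge of the scatter. Compound 3 is accordingly estimated at 15000 nM, with a range from 5000 nM to 40000 nM.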

Compound 3, half-maximal inhibitory concentration: 11000 nM
Estimate against measurement, compound 3: 1.4-fold (0.13 log units) above; low and high end bracket the measured number.
By their numbers in this assay, from the lowest: compound 2; then compound 3; then compound 1.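

In this assay, the move from phenyl to 4-chlorophenyl gives a 2.5-fold lower number from compound 1 to compound 3 (0.39 log units; beyond the scatter), so this aromatic carbon para to a large group is a place where one added chlorine atom shifts the number. Among these compounds, this is the first single-place step, and its size lies beyond the usual scatter. No evidence here accounts for the shift. The compounds shown leave open whether an amine, a methoxy group or a carboxylic acid at this carbon would move the number the same way. They also leave open how chloro would act on the other aromatic carbons of this ring.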